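The source may hold more compounds than are shown below. What is called first, only, known or untested is meant among the compounds shown, and "the series" means these compounds.

Measured in an ADME assay on Huh-7 cells (Homo sapiens) for cytotoxicity, with a stated time of 72 h; on this read-out higher numbers stand for lower toxicity in this test and lower numbers for higher toxicity in this test:
- Compound 1 `COc1ccc(/C=C\c2cc(OC)c(OC)c(OC)c2)cc1NC(=O)[C@H](C)NC(=O)[C@H](CCCNC(=N)N)NC(=O)[C@H](CCCCN)NC(=O)c1ccccc1`: 71.6 nM
- Compound 2 `COc1ccc(/C=C\c2cc(OC)c(OC)c(OC)c2)cc1NC(=O)CCNC(=O)[C@H](CCCNC(=N)N)NC(=O)[C@H](CCCNC(=N)N)NC(=O)c1ccccc1`: 156 nM

Compound 1 holds the lowest of these numbers, and compound 2 lies above it by a gap beyond the usual scatter. Compound 3 `COc1ccc(/C=C\c2cc(OC)c(OC)c(OC)c2)cc1NC(=O)[C@H](C)NC(=O)[C@H](CCCNC(=N)N)NC(=O)[C@H](CCCNC(=N)N)NC(=O)c1ccccc1` has not yet been measured. It differs from compound 1 by a group of 4 heavy atoms (1 carbon, 3 nitrogen; no ring) in place of a group of 2 heavy atoms (1 carbon, 1 nitrogen; no ring), on a saturated chain carbon, four bonds along the chain from an amide-type nitrogen and a carbonyl carbon.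

Within the data shown here, no measured step in this assay covers this change, so the data give no direct guide to its size. The only reference is the span from compound 1 at 71.6 nM to compound 2 at 156 nM. A small rise in the number is expected, not beyond the scatter. The estimated change is a 1.5-fold higher number from compound 1 to compound 3 (0.17 log units; within the scatter). For compound 3 the expected value is 105 nM, with an estimated range of 50 nM to 220 nM.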

Compound 3, half-maximal cytotoxic concentration: 191 nM
Beside the measured number, compound 3's estimate is 1.8-fold (0.26 log units) below it; low and high end bracket the measured number.
By their numbers in this assay, from the lowest: compound 1; then compounds 2 and 3 (each within the scatter of the next).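

In this assay the position on a saturated chain carbon, four bonds along the chain from an amide-type nitrogen and a carbonyl carbon, proves sensitive to this exchange. Among these compounds, replacing aminomethyl with the group of 4 heavy atoms (1 carbon, 3 nitrogen) gives a 2.7-fold higher number from compound 1 to compound 3 (0.43 log units; beyond the scatter) and this modest step is the first to isolate a single place. On this read-out the direction means lower toxicity in this test for the compound carrying the larger group, but no supporting measurement bears on the origin of the step.

Going by these compounds, a carboxylic acid or a hydroxyl group at this place remains open, as does a longer chain ending in an amine. On these data alone, whether the same exchange gives a similar step on other variants of the shared core also remains open.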